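Methoxy for Trifluoromethyl: One Number and an Expectation

The compounds below may be only part of what the source reports. "The series", "measured", "known", "first", "only" and "open" are said of these compounds alone.

The set holds three measured entries on a shared core and one compound still to be tested. Compound 1 `CC(=O)c1cccc(Nc2ccnc(SCC(=O)c3ccc(-c4ccccc4)cc3)n2)c1` was entered into a functional assay on RXF 393 cells (Homo sapiens) for inhibition, read by sulforhodamine B assay, with a stated time of 48 h, tested at 10 uM (a higher number here means more inhibition of growth at the concentration tested, a lower number less inhibition of growth), yet for compound 1 the outcome stands as "not determined" (no result reported). Compound 3 `CCOC(=O)c1ccc(Nc2ccnc(SCC(=O)c3ccc([N+](=O)[O-])cc3)n2)cc1` fares the same way, its entry in this assay reading "not determined" (no result reported). Only compound 2 `CC(=O)c1cccc(Nc2ccnc(SCC(=O)c3ccc(C(F)(F)F)cc3)n2)c1` carries a number: in this assay compound 2 gives 11%. With one value and two blank entries, compound 2 stands alone, and no order among the three can be drawn.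

Compound 4 `COc1ccc(C(=O)CSc2nccc(Nc3cccc(C(C)=O)c3)n2)cc1` is the untested partner of compound 2. It differs from compound 2 in a single place: methoxy in place of trifluoromethyl on an aromatic carbon. Among the measured compounds shown here, no step between measured compounds exists to guide the size of such a change. The account therefore expects the step from compound 2 to compound 4 to be modest, a number 1 percentage points higher from compound 2 to compound 4 (within the scatter), and not clearly beyond the usual scatter in either direction. For compound 4 an inhibition of about 12% is estimated, expected to fall between 0% and 30%.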

Compound 4, percent growth inhibition at one concentration: 14%
Compound 4: middle estimate off by 2 percentage points, on the low side, and the stated range covers the measured number.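

Among the compounds shown here, the step from trifluoromethyl to methoxy gives the first reading of a change at this position, on an aromatic carbon para to a large group. In this assay, going from 4-(trifluoromethyl)phenyl to 4-methoxyphenyl gives a number 3 percentage points higher from compound 2 to compound 4 (within the scatter), so this exchange of groups does not separate the two compounds, although the group that enters has fewer heavy atoms and a hydrogen-bond acceptor that the group leaving lacks. No measurement at hand offers an explanation for this result.

This single step cannot show whether the position tolerates substitution in general, or whether inhibition at the tested concentration depends on the group there at all. On these data alone, it remains open how an amine, a carboxylic acid or a longer alkyl chain at the same place would read in this assay against compound 2 and compound 4.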